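This account rests on a few compounds, and the source may have more. Where it says the series, first, only, none or still open, it means among the compounds named here.

Compound 1, with the structure `CC1CCN(c2c(S(=O)(=O)c3ccc(Cl)cc3)cnc3ccc(F)cc23)CC1`, carries a 4-methylpiperidine and a 4-chlorophenylsulfonyl on a shared core that bears a fluoro substituent. In an assay on isolated protein for displacement of a labelled ligand from metabotropic glutamate receptor 5 (Homo sapiens), with a stated time of 60 min, tested at 1 uM (a higher number here means more inhibition at the concentration tested (going by the name of the read-out), a lower number less inhibition), compound 1 gives 80%, the lowest of the three numbers measured. Its two neighbours alter the fluoro on the core: compound 2, `COc1ccc2ncc(S(=O)(=O)c3ccc(Cl)cc3)c(N3CCC(C)CC3)c2c1`, gives 91%, and compound 3, `CC1CCN(c2c(S(=O)(=O)c3ccc(Cl)cc3)cnc3ccc(Cl)cc23)CC1`, gives 92%. The steps of a number 11 percentage points higher from compound 1 to compound 2 (beyond the scatter) and a number 12 percentage points higher from compound 1 to compound 3 (beyond the scatter) are modest, while a number 1 percentage points higher from compound 2 to compound 3 (within the scatter) is within the scatter.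

Compound 4, `COc1cccc(S(=O)(=O)c2cnc3ccc(F)cc3c2N2CCC(C)CC2)c1`, differs from compound 1 elsewhere: 3-methoxyphenyl in place of 4-chlorophenyl on a sulfonyl sulfur. Among the compounds with values here, none of the three measured compounds varies this part of the molecule; all of them carry the 4-chlorophenyl, so no measured step bears on this change, and the steps seen at the fluoro position say nothing about it. The writer expects compound 4 to give an estimated 65%, with a range from 30% to 90%, which would be a step of a number 15 percentage points lower from compound 1 to compound 4 (beyond the scatter) and could go either way once the measurement is in.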

Compound 4, a percentage reported as inhibition, at one concentration (the size of the read-out at that concentration, not a potency): 90%
For compound 4 the middle estimate is 25 percentage points below the measured one; the measured number falls inside the stated range.
By their numbers in this assay, from the lowest: compounds 1, 4, 2 and 3 (each within the scatter of the next, the first and the last beyond it).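

Within the data shown here, at the sulfonyl sulfur, the first change to this part of the molecule, 3-methoxyphenyl in place of 4-chlorophenyl, gives in this assay a number 10 percentage points higher from compound 1 to compound 4 (within the scatter). In this one pair, then, the 4-chlorophenyl is not required for the inhibition seen at the tested concentration, since a differently substituted aromatic ring with a hydrogen-bond acceptor in its methoxy group leaves the read-out of compound 4 level with that of compound 1. Nothing measured here accounts for this level number, and no supporting data bear on it.

From the compounds shown here alone, whether the 3-methoxyphenyl also leaves the number level alongside the core substituents of compound 2 and compound 3 remains open. Also open, going by these compounds, is how the sulfonyl sulfur would accept a pyridyl ring, an unsubstituted phenyl or a plain methyl group in place of these rings.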